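Methylphenyl for Chlorophenyl on an Acylhydrazone Amide

The source may report more compounds than this note shows. Statements on the series, on what has been measured and on what is new or still open speak of the compounds shown alone.

Measured so far:
compound 1, `CC(/C=N/Nc1ccc([N+](=O)[O-])cc1)=N\NC(=O)c1ccccc1Cl`: > 12000 nM in a functional assay on cells (Splenocyte, Mus musculus, strain BALB/c) for inhibition, read by scintillation counting and thymidine incorporation, with a stated time of 72 h; on this read-out higher numbers stand for weaker inhibition and lower numbers for stronger inhibition
compound 2, `CC(/C=N/N(C)c1ccc([N+](=O)[O-])cc1)=N\NC(=O)c1ccccc1O`: 3120 nM

Of the compounds shown here, two have been measured. Compound 1 stands at the limit of > 12000 nM in this assay, at which 1 of the 2 values shown sits, and has no number of its own. Compound 2, by contrast, gives 3120 nM. Going by the values given here, compound 2 differs from compound 1 in more than one place, so the two values show only that compound 2 has a measured number where compound 1 reaches a limit, and nothing about any single change.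

Compound 3, `CC(/C=N/Nc1ccc([N+](=O)[O-])cc1)=N\NC(=O)c1cccc(C)c1`, has not yet been measured. It differs from compound 1 by 3-methylphenyl in place of 2-chlorophenyl on a carbonyl carbon. Among the compounds with values here, no measured pair isolates this change, so the data give no direction and no size for it. The expected step that the limit leaves unreadable from compound 1 to compound 3 is therefore close to none beyond the scatter, and a limit rather than a number is a real possibility for compound 3 as well. For compound 3 the estimate is 15000 nM, with a range from 4000 nM to 50000 nM.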

Compound 3, half-maximal inhibitory concentration: > 12000 nM
Compound 3: only a limit was reported (the forecaster's own chance of this, stated with the estimate: 60%); the middle value does not contradict the limit.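

Going by these compounds alone, compound 1 and compound 3 each give only a limit in this assay, not a number, so no step between them can be read: the limit of > 12000 nM in this assay, at which 2 of the 3 values shown sit.

On these data alone, whether 3-methylphenyl in place of 2-chlorophenyl on a carbonyl carbon changes the inhibition at all, and in which direction, remains open.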